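This account rests on a few compounds, and the source may have more. Where it says the series, first, only, none or still open, it means among the compounds named here.

Of the compounds shown here, two have been measured in an assay on membranes from brain for displacement of a labelled ligand from Sigma non-opioid intracellular receptor 1 (Cavia porcellus), read by scintillation counting, with a stated time of 120 min; a lower number here means a stronger inhibitor, a higher number a weaker inhibitor. Compound 1 `N#Cc1ccc(-c2scc3c2CCOC32CCN(Cc3ccccc3)CC2)cc1` gives 3.4 nM in this assay. Compound 2 `COC1Cc2cscc2C2(CCN(Cc3ccccc3)CC2)O1` gives 0.22 nM in this assay, and it stands lowest of the two numbers; the gap to compound 1 is beyond the usual scatter, so compound 2 is the stronger binder of the pair. The two structures differ in more than one place, so their values show only that and support no single-change comparison.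

Compound 3 `COC1Cc2c(csc2-c2cccc3ccccc23)C2(CCN(Cc3ccccc3)CC2)O1` has not yet been measured. It differs from compound 2 in one place: naphthalen-1-yl in place of hydrogen on an aromatic carbon. Among the compounds with values here, no measured pair describes a single change of this kind, so the size of the step in this assay is uncertain.

For compound 3 the expectation is that the number rises somewhat, because compound 1, which also carries an aromatic ring on the five-membered aromatic ring with 1 sulfur, gives 3.4 nM while the smaller compound 2 gives 0.22 nM. The step from a 4.5-fold higher number from compound 2 to compound 3 (0.66 log units; beyond the scatter) is therefore estimated as a moderate weakening. Compound 3 is estimated at 1 nM, within a range of 0.2 nM to 5 nM.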

Compound 3, inhibition constant: 5 nM
For compound 3 the middle estimate is 5.0-fold (0.70 log units) below the measured one; measured number inside the range.
By their numbers in this assay, from the lowest: compound 2; then compounds 1 and 3 (each within the scatter of the next).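

In this assay, naphthalen-1-yl in place of hydrogen on the aromatic carbon next to the ring sulfur gives a 23-fold higher number from compound 2 to compound 3 (1.36 log units; beyond the scatter), a large step and well beyond the usual scatter. Within the data shown here, this pair is the first to differ in one place only, so the effect of filling this position can now be read directly rather than inferred from compounds that differ in several places at once. The change clearly weakens binding, yet the position does tolerate a group with two six-membered aromatic rings of carbon only, since compound 3 still gives 5 nM in this assay.

Going by these compounds, a single substituent cannot show how the loss depends on the group placed here, so it remains open whether a methyl group, a chlorine atom or a small amine at the same carbon would keep more of the binding strength of compound 2. Nothing measured here explains why the naphthalen-1-yl group has this effect on binding.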